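Three Glycoside Esters at the Assay Limit, and an Isopentyl Analogue

The source may report more compounds than this note shows. Statements on the series, on what has been measured and on what is new or still open speak of the compounds shown alone.

Compound 1 `C#CCOC(=O)C[C@@H]1C(C(=O)OC)=CO[C@@H](O[C@@H]2O[C@H](CO)[C@@H](O)[C@H](O)[C@H]2O)/C1=C/C` is a glycoside bearing a propargyloxycarbonyl side chain on its shared core. In a functional assay on SK-BR-3 cells (Homo sapiens) for antiproliferative activity, read by MTT assay, with a stated time of 72 h (a higher number here means a weaker inhibitor, a lower number a stronger inhibitor), compound 1 gives > 15000 nM, which is a limit of the assay and not a number. Two acetylated relatives share this picture. Compound 2 `C/C=C1/[C@H](O[C@@H]2O[C@H](COC(C)=O)[C@@H](OC(C)=O)[C@H](OC(C)=O)[C@H]2OC(C)=O)OC=C(C(=O)O)[C@H]1CC(=O)OC` reaches only > 20000 nM in this assay, again a limit. Compound 3 `C/C=C1/[C@H](O[C@@H]2O[C@H](COC(C)=O)[C@@H](OC(C)=O)[C@H](OC(C)=O)[C@H]2OC(C)=O)OC=C(C(=O)OC)[C@H]1CC(=O)SCCC` likewise stops at > 15000 nM, also a limit. So compound 1 stands where every measured member stands: at the edge of what this assay can report, with the limit of > 15000 nM in this assay, at which 2 of the 3 values shown sit, and the limit of > 20000 nM in this assay, at which 1 of the 3 values shown sits, marking the two edges, and no compound yet shows a number at all.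

Compound 4 `C/C=C1/[C@H](O[C@@H]2O[C@H](CO)[C@@H](O)[C@H](O)[C@H]2O)OC=C(C(=O)OC)[C@H]1CC(=O)OCCC(C)C` is the next one to be tested. It differs from compound 1 in one place: isobutyl in place of ethynyl on a saturated chain carbon bound to an oxygen next to a carbonyl group. Cut one bond further out, this is a change from propargyloxycarbonyl to isopentyloxycarbonyl.

With no measured step between any pair of these compounds, there is no observed direction to lean on. The expected step that the limit leaves unreadable from compound 1 to compound 4 is therefore none beyond the usual scatter, and compound 4 is expected to remain at a limit as well. The estimate for compound 4 in this assay is 20000 nM, with a range from 8000 nM to 60000 nM.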

Compound 4, half-maximal inhibitory concentration: 9020 nM
Estimate against measurement, compound 4: 2.2-fold (0.35 log units) above; low and high end bracket the measured number.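

Among the compounds shown here, compound 4 is the first compound in this set to give a number rather than a limit: in this assay compound 4 gives 9020 nM. This shows that the ester side chain, the place where isobutyl stands in for ethynyl on a saturated chain carbon bound to an oxygen next to a carbonyl group, can hold a group that brings the read-out within the range of the assay, and the change from propargyloxycarbonyl to isopentyloxycarbonyl comes with an at least 1.6-fold lower number from compound 1 to compound 4 (0.22 log units; that floor lies within the scatter). The true size of this step cannot be read because compound 1 rests at a limit of the assay and not at a number: the limit of > 15000 nM in this assay, at which 2 of the 4 values shown sit.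

The compounds shown cannot separate the effect of the longer isopentyl chain from that of its branching or of losing the triple bond. A straight pentyl chain, a longer hexyl chain or a chain ending in an amine at the same place would be needed to tell which feature of the isopentyl group goes with the measured number.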